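This account rests on a few compounds, and the source may have more. Where it says the series, first, only, none or still open, it means among the compounds named here.

Of the compounds shown here, three sharing one core have been measured in a functional assay on PC-3 cells (Homo sapiens) for inhibition, read by sulforhodamine B assay, with a stated time of 48 h; on this read-out lower numbers stand for stronger inhibition of growth and higher numbers for weaker inhibition of growth. Compound 1 `COc1cc2nc(-c3ccc(C(F)(F)F)cc3)cc(OCCCN3CCCC3)c2cc1OC` gives 1070 nM, compound 2 `COc1cc2nc(-c3ccc(Cl)cc3)cc(OCCCN3CCCC3)c2cc1OC` gives 1760 nM, and compound 3 `COc1cc2nc(-c3ccc(C(F)(F)F)cc3)cc(OCCCN3CCC(O)CC3)c2cc1OC` gives 3660 nM. Compound 2 thus sits second highest of the three; its gap to compound 1, a 1.6-fold higher number from compound 1 to compound 2 (0.22 log units; within the scatter), is within the scatter, while the number for compound 3 stands further above it. Compound 4 `COc1cc2nc(-c3ccc(Cl)cc3)cc(OCCCN3CCCCC3)c2cc1OC` differs from compound 2 by piperidin-1-yl in place of pyrrolidin-1-yl on a saturated chain carbon, three bonds along the chain from an oxygen on an aromatic ring. Within the data shown here, the only measured step at that position is a 3.4-fold higher number from compound 1 to compound 3 (0.53 log units; beyond the scatter), though that entering ring also carried a hydroxyl, which compound 4 lacks. A small step toward a higher number in this assay, a 1.3-fold higher number from compound 2 to compound 4 (0.12 log units; within the scatter), is therefore expected. Compound 4 is estimated at 2300 nM, ranging from 1000 nM to 5300 nM.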

Compound 4, concentration for 50% growth inhibition: 1740 nM
Estimate against measurement, compound 4: 1.3-fold (0.12 log units) above, within the range that was stated.
By their numbers in this assay, from the lowest: compounds 1, 4 and 2 (each within the scatter of the next); then compound 3.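

Replacing pyrrolidin-1-yl with piperidin-1-yl on the saturated chain carbon gives a 1.0-fold lower number from compound 2 to compound 4 (0.00 log units; within the scatter) in this assay, so this position accepts the six-membered ring with no change beyond the scatter. The earlier step at this position, a 3.4-fold higher number from compound 1 to compound 3 (0.53 log units; beyond the scatter), involved 4-hydroxypiperidin-1-yl, and the unsubstituted ring does not repeat it here, though compound 3 and compound 4 also differ in their aromatic substituent. Nothing available explains why the two rings read alike.

From the compounds shown here alone, whether morpholin-4-yl or an open-chain amine such as diethylamino would read the same remains open. So does the effect of a longer chain.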